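A few compounds are considered here, and "the series" means these few. Any claim that something is new, unique, unknown or untested is made for them only; others in the source may bear on it.

Compound 1 `COc1cc(-c2nnc(SCc3ccccc3F)o2)ccc1O` gives 474000 nM in an ADME assay on cells (Mus musculus, strain BALB/c) for cytotoxicity, read by MTT assay, with a stated time of 24 h (on this read-out lower numbers stand for higher toxicity in this test and higher numbers for lower toxicity in this test), and stands second highest of the three numbers. Compound 2 `COc1cc(-c2nnc(SCc3ccc(F)cc3)o2)ccc1O` gives 685000 nM, a move of a 1.4-fold higher number from compound 1 to compound 2 (0.16 log units; within the scatter), and compound 3 `COc1cc(-c2nnc(SCc3ccccc3)o2)ccc1O` gives 211000 nM, a move of a 2.2-fold lower number from compound 1 to compound 3 (0.35 log units; beyond the scatter). Compound 4 `COc1cccc(CSc2nnc(-c3ccc(O)c(OC)c3)o2)c1` differs from compound 1 by 3-methoxyphenyl in place of 2-fluorophenyl on a saturated chain carbon bound to a sulfur. Within the data shown here, the steps that bear on it are the repositioning of fluoro, which stayed within the scatter, and its removal, which gave a modest drop; no methoxyphenyl on this position has been measured, so the direction of the new group is open. A step of a 1.1-fold lower number from compound 1 to compound 4 (0.05 log units; within the scatter) in this assay is therefore expected, not beyond the scatter. Compound 4 is estimated at 420000 nM, with a range from 200000 nM to 850000 nM.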

Compound 4, half-maximal cytotoxic concentration: 389000 nM
Estimate against measurement, compound 4: 1.1-fold (0.03 log units) above; the range from low to high includes it.
By their numbers in this assay, from the lowest: compounds 3, 4, 1 and 2 (each within the scatter of the next, the first and the last beyond it).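

In this assay, 3-methoxyphenyl on a saturated chain carbon bound to a sulfur stays within the scatter of both fluorinated compounds (a 1.2-fold lower number from compound 1 to compound 4 (0.09 log units; within the scatter) and a 1.8-fold lower number from compound 2 to compound 4 (0.25 log units; within the scatter)). Unlike the fluoro steps from hydrogen, methoxy in place of hydrogen on an aromatic carbon also stays within the scatter (a 1.8-fold higher number from compound 3 to compound 4 (0.27 log units; within the scatter)), so this position accepts a larger substituted phenyl without a step beyond the scatter. Nothing available explains these readings. From the compounds shown here alone, an amine, a carboxylic acid or a longer chain on that carbon remains open, as does any change to the core of compound 1.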